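The source may report more compounds than this note shows. Statements on the series, on what has been measured and on what is new or still open speak of the compounds shown alone.

Working notes on the series. Of the compounds shown here, two have been measured in an assay on isolated protein for inhibition of serine/threonine-protein kinase Chk2 (Homo sapiens), read by mobility shift assay, tested at 30 uM; on this read-out higher numbers stand for more inhibition at the one concentration tested (going by the name of the read-out) and lower numbers for less inhibition. Compound 1 `CC(=O)Nc1nn(C)c2cc(-c3ccccc3)[nH]c(=O)c12` gives 4% in this assay, and compound 2 `Cc1cc2nn(-c3ccccc3)c(N)c2c(=O)[nH]1` gives -4%. The two numbers lie within the scatter of each other, so compound 2 stands on a par with compound 1, and both sit near zero inhibition at the concentration tested.

Compound 3 `Nc1c2c(=O)[nH]c(-c3ccccc3)cc2nn1-c1ccccc1` has not been measured. It differs from compound 2 as follows: phenyl in place of methyl on an aromatic carbon. Among the compounds with values here, no measured pair shows what this exchange does, so the expected step rests only on the near-zero numbers of compound 2 and compound 1.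

The step of a number 9 percentage points higher from compound 2 to compound 3 (within the scatter) is expected to stay within the scatter, with no clear direction. Compound 3 is estimated at 5% in this assay, in the range -10% to 25%.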

Compound 3, a percentage reported as inhibition, at one concentration (the size of the read-out at that concentration, not a potency): -8%
Beside the measured number, compound 3's estimate is 13 percentage points above it, and the stated range covers the measured number.
By their numbers in this assay, from the lowest: compounds 3, 2 and 1 (each within the scatter of the next, the first and the last beyond it).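

Phenyl in place of methyl on the aromatic carbon next to the ring nitrogen is the first exchange in the series that can be read directly, and in this assay it appears as a number 4 percentage points lower from compound 2 to compound 3 (within the scatter) and shows no clear effect. At this position, the entering six-membered aromatic ring of carbon only therefore leaves inhibition near zero at the one concentration tested, as it was with methyl. Nothing at hand explains this flat result.

Within the data shown here, still open is whether this position can affect inhibition at all, as the exchange starts from a compound with almost no inhibition and tests only two carbon groups. An amine or a carboxylic acid on this aromatic carbon, or a longer alkyl chain, would show whether a different kind of group moves the read-out out of the scatter.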